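The compounds below may be only part of what the source reports. "The series", "measured", "known", "first", "only" and "open" are said of these compounds alone.

Measured compounds:
- compound 1, `NC(=O)c1cn(Cc2ccccc2)c2ncnc(N)c12`: 16000 nM
- compound 2, `CCCn1cc(C(N)=O)c2c(N)ncnc21`: 73000 nM
- compound 3, `Cc1ccc(Cn2cc(C(=N)S)c3c(N)ncnc32)cc1`: > 10000 nM

Notes on the series. For the measured compounds named here, in a functional assay on L1210 cells (Mus musculus) for inhibition (a higher number here means a weaker inhibitor, a lower number a stronger inhibitor), compound 1 gives 16000 nM and compound 2 gives 73000 nM; the one measured step, a 4.6-fold higher number from compound 1 to compound 2 (0.66 log units; beyond the scatter), is the only change with a number attached. For compound 3 this assay reports only a limit, > 10000 nM, and the limit of > 10000 nM in this assay, at which 1 of the 3 values shown sits, marks where it sits; how far beyond it compound 3 lies is not known.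

The next compound, compound 4 `Cc1ccc(Cn2cc(C(N)=O)c3c(N)ncnc32)cc1`, is not yet measured. It differs from compound 3 as follows: a group of 3 heavy atoms (1 carbon, 1 nitrogen, 1 oxygen; no ring) in place of a group of 3 heavy atoms (1 carbon, 1 nitrogen, 1 sulfur; no ring), on an aromatic carbon. Going by the values given here, no measured step covers this exchange; the step from compound 1 to compound 2 changes the group on the saturated chain carbon bound to the aromatic nitrogen and says nothing about the carbamoyl. What can be used is that compound 4 shares its carbamoyl with compound 1, which gives 16000 nM, and differs from compound 1 only on the benzyl group. Compound 4 is therefore expected to land near compound 1, with no firm direction for the step that the limit leaves unreadable from compound 3 to compound 4 from the limit of compound 3. The estimate for compound 4 in this assay is 15000 nM, between 5000 nM and 50000 nM.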

Compound 4, half-maximal inhibitory concentration: 20000 nM
Compound 4: middle estimate off by 1.3-fold (0.12 log units), on the low side; the measured number falls inside the stated range.
By their numbers in this assay, from the lowest: compounds 1 and 4 (each within the scatter of the next); then compound 2.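

In this assay, methyl in place of hydrogen on the aromatic carbon of the benzyl group leaves no readable difference: a 1.3-fold higher number from compound 1 to compound 4 (0.10 log units; within the scatter). Against the ethyl group of compound 2, the 4-methylphenyl group gives a 3.7-fold lower number from compound 2 to compound 4 (0.56 log units; beyond the scatter), so the earlier gap between phenyl and ethyl on that saturated chain carbon is matched by a second aryl member. The exchange of the sulfur-bearing group for carbamoyl on the aromatic carbon cannot be read, because compound 3 stands only at a limit: the limit of > 10000 nM in this assay, at which 1 of the 4 values shown sits.

On these data alone, what a nitrile or a carboxylic acid in place of carbamoyl on that aromatic carbon would give remains open. Also open, as far as these compounds go, is whether a longer chain in place of ethyl, or a chlorine atom in place of the methyl on the phenyl ring, would move the number beyond the scatter.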